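The compounds below may be only part of what the source reports. "The series", "measured", "known", "first", "only" and "open" are said of these compounds alone.

In a functional assay on MCF7 cells (Homo sapiens) for inhibition, read by sulforhodamine B assay, with a stated time of 72 h (a lower number here means a stronger inhibitor, a higher number a weaker inhibitor), compound 1 `CC(C)Cc1ccc(C(C)c2nnc3n2N=C(c2ccc(Cl)cc2)CS3)cc1` gives 8800 nM and compound 2 `CC(c1ccc(-c2ccccc2)c(F)c1)c1nnc2n1N=C(c1ccc(Cl)cc1Cl)CS2` gives 7600 nM. These two numbers lie within the usual scatter of repeated measurements, so neither compound can be ranked above the other, and compound 1 stands level with compound 2.

Compound 3 `CC(C)Cc1ccc(C(C)c2nnc3n2N=C(c2ccc(F)cc2)CS3)cc1` keeps the core of compound 1 and changes it in one place: fluoro in place of chloro on an aromatic carbon. In words, this is fluoro in place of chloro on an aromatic carbon, turning the 4-chlorophenyl into a 4-fluorophenyl.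

Within the data shown here, no pair of measured compounds shows this swap, so there is no direct precedent for its size. With so small an exchange, no change beyond the scatter is expected in this assay. The estimated step is a 1.1-fold higher number from compound 1 to compound 3 (0.03 log units; within the scatter). Compound 3 is expected at about 9500 nM, within an estimated range of 4500 nM to 20000 nM.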

Compound 3, half-maximal inhibitory concentration: 8900 nM
The estimate for compound 3 lay 1.1-fold (0.03 log units) above the measured number; measured number inside the range.
By their numbers in this assay, from the lowest: compounds 2, 1 and 3 (each within the scatter of the next).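

In this assay, among these compounds, fluoro in place of chloro on this aromatic carbon, para to a large group, gives a 1.0-fold higher number from compound 1 to compound 3 (0.00 log units; within the scatter), the first step between measured compounds that differ in one place. At this position, then, the 4-chlorophenyl and the 4-fluorophenyl cannot be told apart in this read-out, so this pair offers no handle for ranking the two halogens. Nothing available explains why the two compounds read alike.

From the compounds shown here alone, whether the number responds to a more different group at this position stays open: a methoxy group, an amine or a carboxylic acid in place of the halogen might shift it or might not. A single pair also cannot show whether the same exchange would read alike on compound 2, whose other parts differ from those of compound 1.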